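Benzyl in place of ethyl on one ester of compound 1

This account rests on a few compounds, and the source may have more. Where it says the series, first, only, none or still open, it means among the compounds named here.

Compound 1 `CCOC(=O)C1=C(C)NC(C)=C(C(=O)OCC)C1c1[nH]c(CC)nc1Cl`: 0.158 nM
Compound 2 `CCc1nc(Cl)c(C2C(C(=O)OC3CCCC3)=C(C)NC(C)=C2C(=O)OC2CCCC2)[nH]1`: 0.212 nM

In an assay on ileum for inhibition of Voltage-dependent L-type calcium channel subunit alpha-1C (Cavia porcellus) (a lower number here means a stronger inhibitor, a higher number a weaker inhibitor), compound 1 gives 0.158 nM, the lowest of the two numbers. Its nearest neighbour, compound 2, gives 0.212 nM, a gap within the scatter of repeated measurements, so the two cannot be ranked against each other.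

Compound 3 `CCOC(=O)C1=C(C)NC(C)=C(C(=O)OCc2ccccc2)C1c1[nH]c(CC)nc1Cl` carries phenyl in place of methyl on a saturated chain carbon bound to an oxygen next to a carbonyl group. Going by the values given here, no measured pair shows this change, so only the closeness of compound 1 and compound 2 speaks to it. The step from compound 1 to compound 3 is expected to be small, a 1.3-fold higher number from compound 1 to compound 3 (0.10 log units; within the scatter), with no direction claimed beyond the scatter. Compound 3 is therefore estimated at 0.2 nM, within 0.06 nM to 0.7 nM in this assay.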

Compound 3, half-maximal inhibitory concentration: 2.66 nM
Compound 3: the middle estimate sits 13-fold (1.12 log units) below what was measured, and the stated range ends below it.
By their numbers in this assay, from the lowest: compounds 1 and 2 (each within the scatter of the next); then compound 3.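

In this assay, phenyl in place of methyl on a saturated chain carbon bound to an oxygen next to a carbonyl group gives a 17-fold higher number from compound 1 to compound 3 (1.23 log units; beyond the scatter), so this ester does not accept every group alike. The step is large and lies beyond the scatter, and it comes from a single change to one ester of compound 1. No measurement here accounts for it.

The compounds shown leave open whether the aromatic ring itself matters, which a cyclohexylmethyl ester would test. They also leave open how a phenethyl ester or an ester bearing an amine would read.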